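A few compounds are considered here, and "the series" means these few. Any claim that something is new, unique, unknown or untested is made for them only; others in the source may bear on it.

Measured so far:
compound 1 `c1ccc(-c2ccc(CCc3nc(CC4CCCC4)c[nH]3)cc2)nc1`, 425 nM;
compound 2 `CCC(C)(C)Cc1c[nH]c(CCc2ccc(N3CCCCC3)cc2)n1`, 171 nM;
compound 3 `O=C(O)c1cc(F)c(F)cc1-c1ccc(CCc2nc(CC3CCCCC3)c[nH]2)cc1`, 63 nM.

All three were tested in a functional assay on HEK293 cells for agonist activity at Bombesin receptor subtype-3 (Homo sapiens), read by luminescence and calcium flux, with a stated time of 10 min; a higher number here means that more compound is needed for the effect, a lower number that less compound is needed. Among these three numbers compound 2 stands second highest: compound 1 gives a higher number, beyond the scatter, and compound 3 a lower number, also beyond the scatter. Compound 4 `CCC(C)(C)Cc1c[nH]c(CCc2ccc(-c3cccnc3C(=O)O)cc2)n1` has not yet been measured. It differs from compound 2 in one place: 2-carboxypyridin-3-yl in place of piperidin-1-yl on an aromatic carbon. Compound 3 also carries a carboxylic acid on an aromatic ring at that position and gives the lowest number seen, 63 nM. Compound 4 is therefore expected to give 90 nM, within a range from 35 nM to 250 nM. The step of a 1.9-fold lower number from compound 2 to compound 4 (0.28 log units; within the scatter) is expected to be downward and beyond the scatter.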

Compound 4, half-maximal effective concentration: 1260 nM
Compound 4: middle estimate off by 14-fold (1.15 log units), on the low side; the measured number lies above the stated range.
By their numbers in this assay, from the lowest: compound 3; then compound 2; then compound 1; then compound 4.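

In this assay, placing 2-carboxypyridin-3-yl instead of piperidin-1-yl on this aromatic carbon gives a 7.4-fold higher number from compound 2 to compound 4 (0.87 log units; beyond the scatter), so more compound is needed for the effect. The position is therefore sensitive to what sits there, and this replacement loses potency rather than gaining it. Nothing measured here gives a reason for the step.

On these data alone, the pyridine ring and the carboxylic acid enter together, so their separate contributions remain open. A methyl ester in place of the acid, or a plain phenyl ring, at this position would help to tell them apart.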